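The compounds below may be only part of what the source reports. "The series", "measured", "known", "first", "only" and "open" are said of these compounds alone.

Measured compounds:
- compound 1 `Cc1ccccc1-n1cc(-c2cccc(NS(=O)(=O)c3c[nH]c(=O)[nH]c3=O)c2)nn1`: 5470 nM
- compound 2 `O=c1[nH]cc(S(=O)(=O)Nc2cccc(-c3cn(-c4ccc(Cl)cc4)nn3)c2)c(=O)[nH]1`: 1730 nM
- compound 3 `O=c1[nH]cc(S(=O)(=O)Nc2ccc(-c3cn(-c4ccccc4)nn3)cc2)c(=O)[nH]1`: 7170 nM

All three share one core and are read in a functional assay on A549 cells (Homo sapiens) for antiproliferative activity, read by MTT assay, with a stated time of 24 h; a higher number here means a weaker inhibitor, a lower number a stronger inhibitor. Compound 3 gives the highest of the three numbers in this assay; its nearest neighbour is compound 1, whose number is lower but within the scatter, while compound 2 lies beyond the scatter below it. Among the measured compounds shown here, the only single-place step among the measured set is a 3.2-fold lower number from compound 1 to compound 2 (0.50 log units; beyond the scatter), a modest change on the aromatic nitrogen substituent.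

Compound 4 `O=c1[nH]cc(S(=O)(=O)Nc2ccc(-c3cn(-c4ccccc4F)nn3)cc2)c(=O)[nH]1` is not yet measured. It differs from compound 3 in one place: fluoro in place of hydrogen on an aromatic carbon. For the measured compounds named here, the change sits on the same aryl ring that was varied between compound 1 and compound 2, but no measured step exchanges hydrogen for fluoro, so the bearing of a 3.2-fold lower number from compound 1 to compound 2 (0.50 log units; beyond the scatter) is indirect: it shows that substitution on that ring can shift the number by a modest amount, in either direction as far as these data tell. A single fluoro on an aromatic carbon is a small change, and the expected step of a 1.2-fold lower number from compound 3 to compound 4 (0.08 log units; within the scatter) is therefore no larger than the scatter, with no preferred direction. Compound 4 is estimated at 6000 nM in this assay, with a range of 2500 nM to 14000 nM.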

Compound 4, half-maximal inhibitory concentration: 5960 nM
Compound 4: the middle estimate sits 1.0-fold (0.00 log units) above what was measured, within the range that was stated.
By their numbers in this assay, from the lowest: compound 2; then compounds 1, 4 and 3 (each within the scatter of the next).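

In this assay, among the compounds shown here, the first direct exchange of hydrogen for fluoro on this aryl ring, phenyl to 2-fluorophenyl, gives a 1.2-fold lower number from compound 3 to compound 4 (0.08 log units; within the scatter), so a single fluoro on this aromatic carbon, ortho to a large group, leaves the number within the scatter in this compound pair. The earlier single-place step, a 3.2-fold lower number from compound 1 to compound 2 (0.50 log units; beyond the scatter), showed that a change of substituent on the aromatic nitrogen can move the number beyond the scatter, whereas the new step shows that not every substitution on this ring does so. No supporting data are available to explain either step.

As far as these compounds go, it remains open whether another group at this same place, such as trifluoromethyl, methoxy or an amine, would give a step beyond the scatter, or whether the flat result is particular to fluoro. Also open, from the compounds shown here alone, is whether the exchange of hydrogen for fluoro would give a step of similar size in the framework shared by compound 1 and compound 2, where the substituted aryl ring is carried differently on the core.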